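Three Limits and One Dichlorophenyl Newcomer

This account rests on a few compounds, and the source may have more. Where it says the series, first, only, none or still open, it means among the compounds named here.

compound 1, `COc1ccc(C(=O)/C=C/c2ccc(Br)cc2)c2c1C=CC(C)(C)O2`: > 10000 nM
compound 2, `COc1ccc(C(=O)/C=C/c2ccc(N(c3ccccc3)c3ccccc3)cc2)c2c1C=CC(C)(C)O2`: > 10000 nM
compound 3, `COc1ccc(C(=O)/C=C/c2ccc(OC)c(OC)c2OC)c2c1C=CC(C)(C)O2`: > 10000 nM

Of the compounds shown here, three sharing the core of compound 1 have been tested in a functional assay on SW-620 cells (Homo sapiens) for antiproliferative activity, read by MTT assay, with a stated time of 24 h; a higher number here means a weaker inhibitor, a lower number a stronger inhibitor. In this assay compound 1 gives > 10000 nM, which is a limit of the assay and not a number. Compound 2 likewise reaches only the limit > 10000 nM. Compound 3 also sits at the limit > 10000 nM. Compound 1 therefore stands nowhere on a scale of numbers: all that is known is the limit of > 10000 nM in this assay, at which 3 of the 3 values shown sit, so the three compounds cannot be ordered against one another.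

The next compound, compound 4 `COc1ccc(C(=O)/C=C/c2ccc(Cl)c(Cl)c2)c2c1C=CC(C)(C)O2`, is built from compound 1 by the change (3,4-dichlorophenyl in place of 4-bromophenyl on a double-bonded chain carbon bound to a double-bonded chain carbon). Among the compounds with values here, no measured step between any two of the tested compounds exists, and none of the three variations at that position moved the value off the limit. The expected step in this assay from compound 1 to compound 4 is therefore none beyond the scatter, and most likely again a limit rather than a number. For compound 4 the estimated value in this assay is 12000 nM, with an expected range from 3000 nM to 40000 nM. This estimate means an expected step that the limit leaves unreadable from compound 1 to compound 4.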

Compound 4, half-maximal inhibitory concentration: 7700 nM
Compound 4: middle estimate off by 1.6-fold (0.19 log units), on the high side; the measured number falls inside the stated range.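

Within the data shown here, at the position on a double-bonded chain carbon bound to a double-bonded chain carbon, 3,4-dichlorophenyl gives the first reading in this assay that is a number and not a limit, which shows that a change at this one place can bring the shared core onto the measurable scale. The change from 4-bromophenyl to 3,4-dichlorophenyl amounts to an at least 1.2-fold lower number from compound 1 to compound 4 (0.11 log units; that floor lies within the scatter), and this printed figure is only a floor, so the true step may be small or considerably larger. Its real size stays unknown because the reading for compound 1 is a limit and not a number, as are two of the other readings: the limit of > 10000 nM in this assay, at which 3 of the 4 values shown sit.

The steps from compound 4 to compound 2 and to compound 3 cannot be read, and the compounds shown do not tell whether both chlorines are needed or whether a lone 4-chlorophenyl or 3-chlorophenyl would give a number too. On these data alone, it also remains open how an amine or a carboxylic acid on this ring would read in this assay, and whether any group at this place can move the value much further from the limit.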